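A few compounds are considered here, and "the series" means these few. Any claim that something is new, unique, unknown or untested is made for them only; others in the source may bear on it.

Measured compounds:
- compound 1 `C=C(Br)C(=O)Nc1cccc(-c2cn3nc(Cc4cccc(OC)c4)sc3n2)c1`, 2500 nM
- compound 2 `Nc1cccc(-c2cn3nc(CCc4ccccc4)sc3n2)c1`, 242000 nM
- compound 3 `COc1cccc(Cc2nn3cc(-c4cccc(N)c4)nc3s2)c1`, 24000 nM

In a functional assay on HeLa cells (Homo sapiens) for inhibition, read by cell counting, with a stated time of 4 days (on this read-out lower numbers stand for stronger inhibition and higher numbers for weaker inhibition), compound 1 gives 2500 nM, the lowest of the three numbers; compound 3 is nearest, a 9.6-fold higher number from compound 1 to compound 3 (0.98 log units; beyond the scatter), and compound 2 is furthest, as compound 2 gives 242000 nM while compound 1 gives 2500 nM.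

Compound 4 `C=C(Br)C(=O)Nc1cccc(-c2cn3nc(-c4ccc(OC)cc4)sc3n2)c1` is not yet measured. It differs from compound 1 by 4-methoxyphenyl in place of 3-methoxybenzyl on an aromatic carbon. For the measured compounds named here, no measured step makes this exact change. The step of a 10-fold lower number from compound 2 to compound 3 (1.00 log units; beyond the scatter) is the only one that touches the same position of the shared core, and it is modest in size. The step of a 9.6-fold higher number from compound 1 to compound 3 (0.98 log units; beyond the scatter) concerns the nitrogen on the other ring and does not bear on the change in compound 4. Going by the values given here, with only one modest step at the relevant position, and none that swaps the saturated chain carbon for a direct aryl link, a step of modest size is expected, direction uncertain, leaning toward a somewhat higher number. Compound 4 is therefore estimated at 4000 nM in this assay, with a range of 800 nM to 20000 nM, which means a step of a 1.6-fold higher number from compound 1 to compound 4 (0.20 log units; within the scatter).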

Compound 4, half-maximal inhibitory concentration: 2300 nM
Compound 4: the middle estimate sits 1.7-fold (0.24 log units) above what was measured, within the range that was stated.
By their numbers in this assay, from the lowest: compounds 4 and 1 (each within the scatter of the next); then compound 3; then compound 2.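

In this assay the aromatic carbon next to the ring nitrogen and the ring sulfur accepts either aryl group with the (1-bromoethenyl)carbonyl group in place, as 4-methoxyphenyl in place of 3-methoxybenzyl gives a 1.1-fold lower number from compound 1 to compound 4 (0.04 log units; within the scatter) and leaves the two compounds indistinguishable. The saturated chain carbon is therefore not required for this level of inhibition in this pair, although the same step also changes the place of the methoxy group, so the two changes cannot be separated. No measurement available here accounts for this result.

Still open, going by these compounds, is whether 4-methoxyphenyl would give a similar number alongside the free amine of compound 3. Also open, on these data alone, is how a carboxylic acid or a morpholine ring would behave at this aromatic carbon.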